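Removing an Acetyl Group: Expected Effect on Growth Inhibition

A few compounds are considered here, and "the series" means these few. Any claim that something is new, unique, unknown or untested is made for them only; others in the source may bear on it.

Three compounds have been measured in a functional assay on HeLa cells (Homo sapiens) for antiproliferative activity, read by sulforhodamine B assay, with a stated time of 48 h; a higher number here means a weaker inhibitor of growth, a lower number a stronger inhibitor of growth:
compound 1 `CC1(C)O[C@H]2[C@H](OCc3noc(-c4ccc([N+](=O)[O-])cc4)n3)O[C@H](CO)[C@H]2O1` gives 99000 nM;
compound 2 `CC(=O)OC[C@H]1O[C@@H](OCc2noc(-c3ccc([N+](=O)[O-])cc3)n2)[C@@H]2OC3(CCCC3)O[C@@H]21` gives 17000 nM;
compound 3 `Clc1ccc(-c2nc(CO[C@@H]3O[C@H](CSc4ncn[nH]4)[C@H]4OC5(CCCC5)O[C@@H]34)no2)cc1` gives 14000 nM.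

Compound 2 holds the second highest of these three numbers. Compound 3 sits within the usual scatter of it, so the two cannot be told apart, while compound 1 lies higher by a margin beyond the scatter.

Compound 4 `O=[N+]([O-])c1ccc(-c2nc(CO[C@@H]3O[C@H](CO)[C@H]4OC5(CCCC5)O[C@@H]34)no2)cc1` has not yet been tested in this assay. It differs from compound 2 in one place: hydrogen in place of acetyl on an oxygen on a saturated carbon. Within the data shown here, no measured pair shows this same change, so there is no direct guide. The step of a 1.5-fold higher number from compound 2 to compound 4 (0.17 log units; within the scatter) is therefore expected to be small and not clearly beyond the scatter, with a slight lean toward a higher number. Compound 4 is estimated at 25000 nM, within 8000 nM to 80000 nM.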

Compound 4, concentration for 50% growth inhibition: 15000 nM
The estimate for compound 4 lay 1.7-fold (0.22 log units) above the measured number; measured number inside the range.
By their numbers in this assay, from the lowest: compounds 3, 4 and 2 (each within the scatter of the next); then compound 1.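

Among these compounds, replacing acetoxymethyl with hydroxymethyl gives a 1.1-fold lower number from compound 2 to compound 4 (0.05 log units; within the scatter) in this assay, the first step at this position that can be read directly. In this pair, the acetyl group on the oxygen can therefore be removed with no change that this assay can distinguish. Nothing on hand speaks to the reason for this match.

Going by these compounds, it remains open whether an amine or a carboxylic acid in place of the hydroxy group would also leave the number within the scatter. A longer chain in place of the acetyl group is equally untested by these compounds, and this single pair cannot show whether the same holds on other cores.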